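Aryl-pyrazole cyclic amines: fluoro for methoxy, compound 4

The compounds below may be only part of what the source reports. "The series", "measured", "known", "first", "only" and "open" are said of these compounds alone.

Measured so far in an assay on isolated protein for binding affinity to 5-hydroxytryptamine receptor 1E (Homo sapiens); a higher number here means a weaker inhibitor, a lower number a stronger inhibitor:
Compound 1 `COc1cccc(-c2n[nH]cc2N2CCCNCC2)c1`: compound 1 reaches only the limit of the assay, > 10000 nM.
Compound 2 `c1ccc(-c2n[nH]cc2N2CCCNCC2)cc1`: compound 2 likewise gives only the limit, > 10000 nM.
Compound 3 `COc1ccc(-c2n[nH]cc2N2CCNCC2)cc1`: compound 3 also stops at the limit, > 10000 nM.

Compound 3 therefore stands at the limit, with no number in this assay. Going by the values given here, the one single-point step, a step that the two limits leave unreadable from compound 1 to compound 2, cannot be read because both ends sit at the limit of > 10000 nM in this assay, at which 3 of the 3 values shown sit. Compound 4 `Fc1ccc(-c2n[nH]cc2N2CCNCC2)cc1` differs from compound 3 by fluoro in place of methoxy on an aromatic carbon. Among the compounds with values here, no measured step touches a change of this kind, and no compound has yielded a number that could anchor a direction. Compound 4 is therefore expected to remain at the limit as well, estimated at 20000 nM with a range of 5000 nM to 100000 nM. The step from compound 3 to compound 4 is expected to be a step that the limit leaves unreadable from compound 3 to compound 4, nothing readable beyond the scatter.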

Compound 4, inhibition constant: > 10000 nM
Compound 4 ended at the assay's limit; the forecaster's own chance of this, stated with the estimate: 85%; the middle value is on the limit's open side.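

Compound 3 and compound 4 give no readable step, as both stop at the same assay limit: the limit of > 10000 nM in this assay, at which 4 of the 4 values shown sit.

Which change to the shared core, if any, would give a number in this assay instead of a limit stays open.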